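Adding Phenoxy to Compound 1

The source may hold more compounds than are shown below. What is called first, only, known or untested is meant among the compounds shown, and "the series" means these compounds.

In an ADME assay on L6 cells (Rattus norvegicus) for cytotoxicity, read by fluorescence and resazurin assay, with a stated time of 70 h (on this read-out higher numbers stand for weaker inhibition and lower numbers for stronger inhibition), compound 1 (`N=C(N)Nc1ccc2[nH]c(-c3ccccc3)nc2c1`) gives > 100 ug/mL as a limit and not a number. Compound 3 (`N=C(N)Nc1ccc2[nH]c(-c3ccc(C(=O)O)cc3)nc2c1`) also gives only a limit, > 100 ug/mL in this case. Compound 1 thus stands at the limit of > 100 ug/mL in this assay, at which 2 of the 3 values shown sit, and has no exact value. Compound 2 (`N=C(N)Nc1ccc2[nH]c(-c3ccc(Cl)cc3)nc2c1`) gives 71.1 ug/mL as a number. Compound 4 (`N=C(N)Nc1ccc2[nH]c(-c3ccccc3Oc3ccccc3)nc2c1`) has phenoxy in place of hydrogen on an aromatic carbon, a difference counted as phenoxy in place of hydrogen on an aromatic carbon here. Chloro in place of hydrogen gives an at least 1.4-fold lower number from compound 1 to compound 2 (0.14 log units; that floor lies within the scatter) as the closest measured step. Carboxy gives a step that the two limits leave unreadable from compound 1 to compound 3 as its step from hydrogen, and an at least 1.4-fold higher number from compound 2 to compound 3 (0.14 log units; that floor lies within the scatter) as its step from chloro. Among the measured compounds shown here, with compound 2 at 71.1 ug/mL as the only guide, a moderate move towards lower numbers in this assay is expected. The expected change is an at least 2.5-fold lower number from compound 1 to compound 4 (0.39 log units; beyond the scatter) on this estimate. Compound 4 is estimated at 40 ug/mL (expected range 10 ug/mL to 100 ug/mL).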

Compound 4, half-maximal inhibitory concentration: 51.6 ug/mL
The estimate for compound 4 lay 1.3-fold (0.11 log units) below the measured number; the measured number falls inside the stated range.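

In this assay, phenoxy on an aromatic carbon, ortho to a large group, gives an at least 1.9-fold lower number from compound 1 to compound 4 (0.28 log units; that floor lies within the scatter). Among the compounds shown here, this is the first sign that this place on the ring takes a group of that size and leaves a measured number, though the step remains a floor. Compound 1 has only a limit and no exact value, so the full size of the step stays unknown: the limit of > 100 ug/mL in this assay, at which 2 of the 4 values shown sit.

Going by these compounds, whether the oxygen or the added ring carries the step stays open. So does what a methoxy or an amine at this place would give.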